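The source may hold more compounds than are shown below. What is called first, only, known or untested is meant among the compounds shown, and "the series" means these compounds.

In a functional assay on HCT-116 cells (Homo sapiens) for antiproliferative activity, read by sulforhodamine B assay, with a stated time of 48 h (on this read-out higher numbers stand for weaker inhibition of growth and lower numbers for stronger inhibition of growth), compound 1 (`O=C(Nc1ccccc1)c1ccc(CNC2=C(Cl)C(=O)c3ccccc3C2=O)cc1`) gives only the assay limit > 10000 nM. Compound 2 (`O=C(Nc1ccc(F)cc1)c1ccc(CNC2=C(Cl)C(=O)c3ccccc3C2=O)cc1`) likewise reaches only the limit > 10000 nM in this assay. The step that the two limits leave unreadable from compound 1 to compound 2 is therefore not readable, both values sitting at the limit of > 10000 nM in this assay, at which 2 of the 2 values shown sit. Compound 3 (`O=C(Nc1ccncc1)c1ccc(CNC2=C(Cl)C(=O)c3ccccc3C2=O)cc1`) carries pyridin-4-yl in place of 4-fluorophenyl on an amide-type nitrogen. No measured step bears on this change; the only one shown is unreadable, so no shift beyond the scatter can be argued from the series. Compound 3 is expected to remain at the limit, with the step that the limit leaves unreadable from compound 2 to compound 3 nominal. In this assay compound 3 is estimated at 15000 nM, range 3000 nM to 60000 nM.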

Compound 3, concentration for 50% growth inhibition: 4300 nM
Compound 3: the middle estimate sits 3.5-fold (0.54 log units) above what was measured; measured number inside the range.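

On the amide-type nitrogen, the change to pyridin-4-yl gives the first shift that can be read in this assay (an at least 2.3-fold lower number from compound 2 to compound 3 (0.36 log units; beyond the scatter)). The same holds against the unsubstituted phenyl (an at least 2.3-fold lower number from compound 1 to compound 3 (0.36 log units; beyond the scatter)). Both steps remain open-ended, and compound 3 alone carries a measured number, the other two values being limits: the limit of > 10000 nM in this assay, at which 2 of the 3 values shown sit.

Going by these compounds, how far the shift extends is unknown, as is whether it depends on the ring nitrogen of pyridin-4-yl. Pyridin-3-yl, pyridin-2-yl or 4-aminophenyl on the same amide-type nitrogen would bear on this.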